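This account rests on a few compounds, and the source may have more. Where it says the series, first, only, none or still open, it means among the compounds named here.

Working notes on the series built on the shared core of compound 1 `C=C1C=CC(=O)[C@@H]2[C@H](Cc3ccc(OCOC)c(F)c3)CC[C@H]12`. In a functional assay on NCI-H460 cells (Homo sapiens) for antiproliferative activity, with a stated time of 72 h (on this read-out lower numbers stand for stronger inhibition and higher numbers for weaker inhibition), compound 1 gives 106 nM. Compound 2 `C=C1C=CC(=O)[C@@H]2[C@H](Cc3ccccc3)CC[C@H]12`, with no substituent on its aromatic ring, gives 678 nM. Compound 3 `C=C1C=CC(=O)[C@@H]2[C@H](Cc3ccc(F)c(F)c3)CC[C@H]12` gives 511 nM. That value lies within the scatter of compound 2 and clearly above the number of compound 1.

Compound 4 `C=C1C=CC(=O)[C@@H]2[C@H](Cc3ccc(OC)c(F)c3)CC[C@H]12` follows from compound 3 with methoxy in place of fluoro on an aromatic carbon, ortho to a fluoro group and para to a large group: methoxy in place of fluoro on an aromatic carbon.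

Within the data shown here, one measured step bears on this change: a 4.8-fold higher number from compound 1 to compound 3 (0.68 log units; beyond the scatter), with fluoro in place of methoxymethoxy on an aromatic carbon. Compound 4 reverses that replacement only in part, since methoxy enters rather than methoxymethoxy. Among the measured compounds shown here, no measurement yet shows how much of that step depends on the full methoxymethoxy group. A partial return toward compound 1 is therefore expected in this assay, meaning a lower number than for compound 3, but probably a smaller move than the measured step. The expected change is a 2.4-fold lower number from compound 3 to compound 4 (0.39 log units; beyond the scatter). For compound 4 the estimated value is 210 nM, with an expected range of 90 nM to 500 nM.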

Compound 4, half-maximal inhibitory concentration: 2.62 nM
Estimate against measurement, compound 4: 80-fold (1.90 log units) above; measured number outside the range, below it.
By their numbers in this assay, from the lowest: compound 4; then compound 1; then compounds 3 and 2 (each within the scatter of the next).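

In this assay the choice of group on this aromatic carbon, ortho to a fluoro group and para to a large group, matters far more than the earlier step of a 4.8-fold higher number from compound 1 to compound 3 (0.68 log units; beyond the scatter) could show: methoxy in place of fluoro gives a 200-fold lower number from compound 3 to compound 4 (2.29 log units; beyond the scatter). The full methoxymethoxy group is also not needed for a low number at this position, since the change to methoxy gives a 40-fold lower number from compound 1 to compound 4 (1.61 log units; beyond the scatter), so the shorter group stands well below both methoxymethoxy and fluoro here, and the three groups do not fall in order of their heavy-atom count. No measured data on these compounds offer an explanation for either large step.

On these data alone, it remains open whether this low number is particular to methoxy or extends to other groups on the same aromatic carbon, such as ethoxy, hydroxyl or an amine. Also open, as far as these compounds go, is how much the result depends on the fluoro group ortho to the methoxy, which could be tested by a compound with hydrogen or chlorine on that carbon while the methoxy stays in place.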